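Small Steps So Far, a Larger Swap Ahead

The compounds below may be only part of what the source reports. "The series", "measured", "known", "first", "only" and "open" are said of these compounds alone.

Measured so far in a functional assay on HT-29 cells (Homo sapiens) for inhibition, read by MTT assay, with a stated time of 48 h (a lower number here means a stronger inhibitor, a higher number a weaker inhibitor), are three compounds:
- compound 1 `COc1ccc(-n2c(SCc3ccc(F)cc3)nnc2-c2cc(OC)c(OC)c(OC)c2)cc1` gives 50700 nM
- compound 2 `COc1cc(-c2nnc(SCc3ccc(C)cc3)n2-c2ccc(N(C)C)cc2)cc(OC)c1OC` gives 27500 nM
- compound 3 `COc1cc(-c2nnc(SCc3ccc(F)cc3)n2-c2ccc(N(C)C)cc2)cc(OC)c1OC` gives 44300 nM

Compound 3 gives 44300 nM and stands second highest of the three numbers, but neither of its measured steps goes beyond the scatter, so it cannot be told apart from the other two.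

Among the measured compounds shown here, compound 4 `COc1cc(-c2nnc(SCC(=O)C3CC3)n2-c2ccc(N(C)C)cc2)cc(OC)c1OC` keeps the shared core and carries cyclopropylcarbonyl in place of 4-fluorophenyl on a saturated chain carbon bound to a sulfur as its one change.

For the measured compounds named here, two measured steps bear on this only loosely. Fluoro in place of methyl, a change within the group that leaves, gave a 1.6-fold higher number from compound 2 to compound 3 (0.21 log units; within the scatter) and is the closer guide. Dimethylamino in place of methoxy, at a different place, gave a 1.1-fold lower number from compound 1 to compound 3 (0.06 log units; within the scatter) as well. Going by the values given here, both are small, but neither replaces a whole group, and no measured compound carries a carbonyl on that chain.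

Going by these compounds, no step beyond the scatter is therefore expected in this assay and the direction stays open. The estimated step is a 1.1-fold higher number from compound 3 to compound 4 (0.05 log units; within the scatter) and remains a rough expectation. For compound 4 the expected value is about 50000 nM with an estimated range of 18000 nM to 130000 nM kept wide on purpose.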

Compound 4, half-maximal inhibitory concentration: > 60000 nM
Compound 4 was reported as a limit (the forecaster's own chance of this, stated with the estimate: 15%); middle value at least 1.2-fold (0.07 log units) away from the limit.
By their numbers in this assay, from the lowest: compounds 2, 3 and 1 (each within the scatter of the next). At a limit, above all of these: compound 4.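

Compound 4 is the only compound shown in which cyclopropylcarbonyl, rather than a substituted phenyl, sits on the saturated chain carbon bound to a sulfur, and in this assay it is reported as a limit, not as a number: the limit of > 60000 nM in this assay, at which 1 of the 4 values shown sits.

Swapping out 4-methylphenyl gives an at least 2.1-fold higher number from compound 2 to compound 4 (0.33 log units; beyond the scatter), the only step shown that clears the usual scatter, so the group at this position can move the number in a way the earlier single changes could not show. Swapping out 4-fluorophenyl gives an at least 1.3-fold higher number from compound 3 to compound 4 (0.13 log units; that floor lies within the scatter), but this is only a floor, so the true size of that step remains unknown and it cannot be said to differ from the scatter.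

The change replaces a phenyl ring with a smaller ring and also adds a carbonyl, and the compounds shown do not reveal which of these parts matters for the weaker result. Going by these compounds, a benzoyl group would keep the carbonyl together with an aromatic ring, while an amine or a longer chain at this position would test different replacements, and how any of these would read in this assay remains open.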